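This account rests on a few compounds, and the source may have more. Where it says the series, first, only, none or still open, it means among the compounds named here.

Measured compounds:
Compound 1, `Cc1cc2c(cc1C(=O)c1ccc(C(=O)OCCCOC(=O)c3ccc(C(=O)Nc4ccc5c(c4)C(C)(C)CCC5(C)C)cc3)cc1)C(C)(C)CCC2(C)C`, gives 14900 nM.
Compound 2, `Cc1cc2c(cc1C(=O)c1ccc(C(=O)NCCCCCCNC(=O)c3ccc(C(=O)Nc4ccc5c(c4)C(C)(C)CCC5(C)C)cc3)cc1)C(C)(C)CCC2(C)C`, gives 95400 nM.
Compound 3, `CCCC(CCC)C(=O)OCCCCOC(=O)c1ccc(C(=O)Nc2ccc3c(c2)C(C)(C)CCC3(C)C)cc1`, gives 914000 nM.

In a functional assay on HL-60 cells (Homo sapiens) for inhibition, read by MTT assay, with a stated time of 48 h (a lower number here means a stronger inhibitor, a higher number a weaker inhibitor), compound 3 stands highest of the three numbers, so it is the weakest inhibitor of this set; its nearest neighbour is compound 2, and compound 1 lies furthest from it, both gaps being beyond the usual scatter. Compound 4, `CCCC(=O)OCCOC(=O)c1ccc(C(=O)Nc2ccc3c(c2)C(C)(C)CCC3(C)C)cc1`, has not yet been measured in this assay. Compound 4 differs from compound 3 in one place: (propylcarbonyl)oxy in place of 2-(((1-propylbutyl)carbonyl)oxy)ethyl on a saturated chain carbon, two bonds along the chain from an oxygen next to a carbonyl group. Within the data shown here, no measured pair shows this kind of change, so the size of the step is open. Compound 4 is expected to stay close to compound 3, with a step of a 1.5-fold lower number from compound 3 to compound 4 (0.18 log units; within the scatter) that need not go beyond the scatter in either direction. Compound 4 is therefore estimated at 600000 nM, in a range from 150000 nM to 2500000 nM.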

Compound 4, half-maximal inhibitory concentration: 6290 nM
Compound 4: the middle estimate sits 95-fold (1.98 log units) above what was measured, outside the stated range (below it).
By their numbers in this assay, from the lowest: compound 4; then compound 1; then compound 2; then compound 3.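

In this assay, putting (propylcarbonyl)oxy in place of 2-(((1-propylbutyl)carbonyl)oxy)ethyl gives a 150-fold lower number from compound 3 to compound 4 (2.16 log units; beyond the scatter). This shows that the group on this saturated chain carbon can matter greatly: the leaving group has 12 heavy atoms and the entering one 6, while both have 2 hydrogen-bond acceptors and no donors.

The compounds shown leave open whether the branched end or the overall chain length carries this step, and how an amine or a carboxylic acid would read at this place. No measurement at hand explains the step.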